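A few compounds are considered here, and "the series" means these few. Any claim that something is new, unique, unknown or untested is made for them only; others in the source may bear on it.

Three compounds share one core and differ only in the aryl group carried on a saturated chain carbon bound to an amine nitrogen. In a functional assay on MCF7 cells (Homo sapiens) for inhibition, read by MTT assay, with a stated time of 72 h (a lower number here means a stronger inhibitor of growth, a higher number a weaker inhibitor of growth), compound 1 `O=S(=O)(NCCCNCc1ccc(Cl)cc1)c1cc(C(F)(F)F)cc(C(F)(F)F)c1` gives 2400 nM. Compound 2 `COc1ccc(CNCCCNS(=O)(=O)c2cc(C(F)(F)F)cc(C(F)(F)F)c2)cc1OC` gives 1900 nM, and compound 3 `O=S(=O)(NCCCNCc1cccc(Cl)c1)c1cc(C(F)(F)F)cc(C(F)(F)F)c1` gives 2600 nM. For the measured compounds named here, compound 3 therefore sits among the other two: the step of a 1.1-fold higher number from compound 1 to compound 3 (0.03 log units; within the scatter) and the step of a 1.4-fold higher number from compound 2 to compound 3 (0.14 log units; within the scatter) are both within the scatter, as is a 1.3-fold lower number from compound 1 to compound 2 (0.10 log units; within the scatter), so no compound is set apart on these numbers.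

Compound 4 `O=S(=O)(NCCCNCc1ccc(Cl)c(C(F)(F)F)c1)c1cc(C(F)(F)F)cc(C(F)(F)F)c1` differs from compound 3 by one change: 4-chloro-3-(trifluoromethyl)phenyl in place of 3-chlorophenyl on a saturated chain carbon bound to an amine nitrogen. The three measured steps all swap this same aryl group, and each stayed within the scatter, so a further swap at the same place is expected to do the same. The estimated step is a 1.1-fold lower number from compound 3 to compound 4 (0.03 log units; within the scatter), with no direction beyond the scatter expected. Compound 4 is therefore estimated at 2400 nM, with a range from 1200 nM to 5000 nM.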

Compound 4, concentration for 50% growth inhibition: 3500 nM
Beside the measured number, compound 4's estimate is 1.5-fold (0.16 log units) below it; the measured number falls inside the stated range.
By their numbers in this assay, from the lowest: compounds 2, 1, 3 and 4 (each within the scatter of the next).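

For the compounds shown here, putting trifluoromethyl in place of hydrogen on an aromatic carbon is the one step in this set that only adds to an aryl group already present, and it gives (a 1.5-fold higher number from compound 1 to compound 4 (0.16 log units; within the scatter)). The aryl group also grows in heavy atoms when 4-chloro-3-(trifluoromethyl)phenyl takes the place of 3-chlorophenyl (a 1.3-fold higher number from compound 3 to compound 4 (0.13 log units; within the scatter)), and the widest gap among the four compounds stays inside the scatter too (a 1.8-fold higher number from compound 2 to compound 4 (0.27 log units; within the scatter)), so this position has so far shown no step that stands out, even with a larger group. Nothing measured here bears on what lies behind these numbers.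

Going by these compounds, whether a pyridine ring, a carboxylic acid on the aryl ring or an amide at this place would move the number beyond the scatter stays open. So does whether a longer chain in the shared core would do so.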